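A few compounds are considered here, and "the series" means these few. Any claim that something is new, unique, unknown or untested is made for them only; others in the source may bear on it.

Of the compounds shown here, three built on a shared core have been tested in a functional assay on MCF7 cells (Homo sapiens) for inhibition, with a stated time of 48 h; on this read-out lower numbers stand for stronger inhibition and higher numbers for weaker inhibition. Compound 1 `Cc1cc(C)cc(Sc2c[nH]c3ccc(Cl)cc23)c1` gives 1200 nM. Compound 2 `COc1cc(Sc2c(C)[nH]c3ccc(Cl)cc23)cc(OC)c1OC` gives 82 nM, and compound 3 `COc1cc(Sc2c[nH]c3ccc(I)cc23)cc(OC)c1OC` gives 68 nM. Compound 3 thus carries the lowest of the three numbers. Its gap to compound 2 is small enough to fall within the usual scatter of repeated measurements, so these two cannot be told apart, whereas compound 1 sits well beyond that scatter with a clearly higher number.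

Compound 4 `COc1cc(Sc2c[nH]c3ccc(OCCO)cc23)cc(OC)c1OC` has not yet been measured. It keeps everything of compound 3 except for one change: 2-hydroxyethoxy in place of iodo on an aromatic carbon. Going by the values given here, compounds 1 and 2 differ from compound 3 in more than one place, so none of the measured pairs isolates what this single position contributes, and the expectation must be cautious.

In this assay, among the compounds with values here, the step from compound 3 to compound 4 is expected to be a moderate rise in the number, probably just beyond the scatter, because the one anchor is compound 3 at 68 nM and the new group has no precedent among the three compounds: a 2.9-fold higher number from compound 3 to compound 4 (0.47 log units; beyond the scatter). Compound 4 is therefore estimated to give 200 nM, with a likely range from 50 nM to 1000 nM.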

Compound 4, half-maximal inhibitory concentration: 95 nM
Estimate against measurement, compound 4: 2.1-fold (0.32 log units) above, within the range that was stated.
By their numbers in this assay, from the lowest: compounds 3, 2 and 4 (each within the scatter of the next); then compound 1.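

In this assay, putting 2-hydroxyethoxy in place of iodo on this aromatic carbon gives a 1.4-fold higher number from compound 3 to compound 4 (0.15 log units; within the scatter), so the two compounds cannot be told apart. Going by these compounds alone, this is the first comparison here that isolates a single place, and it shows that a lone iodine can be exchanged for a chain of 4 heavy atoms, bringing 1 hydrogen-bond donor and 2 hydrogen-bond acceptors, without a difference that stands out from the scatter. Nothing in the data shown explains why two such different groups read alike.

From the compounds shown here alone, this is a single pair, so it remains open whether other groups at this place would also read alike, such as an amine, a carboxylic acid or a longer chain ending in a hydroxyl group. Chloro occurs in compound 1 and compound 2, but both also differ from compound 3 elsewhere, so what chloro alone contributes here is unknown, as is whether the exchange of iodo for 2-hydroxyethoxy would read the same on a different version of the shared core.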